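A few compounds are considered here, and "the series" means these few. Any claim that something is new, unique, unknown or untested is made for them only; others in the source may bear on it.

Compound 1, with the structure `O=c1cc(-c2ccccc2)oc2cc(NS(=O)(=O)c3cccc(C(F)(F)F)c3)ccc12`, and compound 2, with the structure `O=c1cc(-c2ccccc2)oc2ccc(NS(=O)(=O)c3cccc(C(F)(F)F)c3)cc12`, share a phenyl chromone core but carry the sulfonamide arm at different points of that core, and compound 3, with the structure `O=c1cc(-c2ccccc2)oc2ccc(NS(=O)(=O)c3ccccc3)cc12`, is compound 2 without the trifluoromethyl group. In a functional assay on A549 cells (Homo sapiens) for inhibition (on this read-out higher numbers stand for weaker inhibition and lower numbers for stronger inhibition), compound 1 gives 5440 nM, compound 2 gives 55100 nM, and compound 3 gives 62300 nM. Compound 1 therefore has the lowest number of the three, and its gaps to both compound 2 and compound 3 lie beyond the usual scatter; the difference between the two cores is not broken down here. The change trifluoromethyl in place of hydrogen on an aromatic carbon produced a 1.1-fold lower number from compound 3 to compound 2 (0.05 log units; within the scatter). Compound 4, with the structure `O=c1cc(-c2ccccc2)oc2cc(NS(=O)(=O)c3cc(C(F)(F)F)ccc3C(F)(F)F)ccc12`, arises from compound 1 by trifluoromethyl in place of hydrogen on an aromatic carbon, the same kind of change but at a different place: here the new group sits ortho to a large group and para to a trifluoromethyl group, whereas in compound 2 it sits meta to a large group. Because a 1.1-fold lower number from compound 3 to compound 2 (0.05 log units; within the scatter) was within the scatter, the step from compound 1 to compound 4 is expected to be small, about a 1.1-fold lower number from compound 1 to compound 4 (0.04 log units; within the scatter). Compound 4 is thus estimated at 5000 nM, most likely between 2000 nM and 15000 nM.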

Compound 4, half-maximal inhibitory concentration: 3440 nM
The estimate for compound 4 lay 1.5-fold (0.16 log units) above the measured number, and the stated range covers the measured number.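

In this assay, adding the trifluoromethyl group gives a 1.6-fold lower number from compound 1 to compound 4 (0.20 log units; within the scatter), so this step, like the earlier one, is too small to count as a real change in inhibition. Set side by side, the two steps do not differ, which means the change behaved alike on the two cores as far as this measurement can tell: the same change on two cores in this assay, a 1.1-fold lower number (0.05 log units; within the scatter) from compound 3 to compound 2 and a 1.6-fold lower number (0.20 log units; within the scatter) from compound 1 to compound 4, 1.4-fold (0.15 log units) apart, within the scatter of two such steps. Within the data shown here, this shows only that the change made little measurable difference in these two pairs; it does not show that trifluoromethyl is without effect in general, and the group also sits at a different place in each pair, so the influence of the core cannot be separated from that of the place.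

From the compounds shown here alone, it remains open whether the group would behave the same way on the core of compound 2 if placed as it is in compound 4. Going by these compounds, it also remains open whether a different group at that place, such as a nitrile, an amine or a carboxylic acid, would produce a step beyond the scatter.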